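The source may hold more compounds than are shown below. What is called first, only, known or untested is meant among the compounds shown, and "the series" means these compounds.

Series notes. Compound 1 `COc1ccc2nc(C)cc(OC(C)C(=O)Nc3cc(C)cc(C)c3)c2c1` and compound 2 `COc1ccc2nc(C)cc(OCC(=O)Nc3ccc(Br)c(C)c3)c2c1` are built on the same core and carry different groups on the amide nitrogen. In a toxicity assay on HepG2 cells (Homo sapiens) for inhibition, read by CellTiter-Glo, with a stated time of 48 h (on this read-out higher numbers stand for weaker inhibition and lower numbers for stronger inhibition), compound 1 gives 39800 nM. In this assay, among the measured compounds shown here, compound 2 gives 15900 nM, the lowest of the two numbers measured so far; the gap to compound 1 lies beyond the usual scatter. Compound 3 `COc1ccc2nc(C)cc(OCC(=O)Nc3c(C)cncc3C)c2c1` is not yet measured. It differs from compound 2 in one place: 3,5-dimethylpyridin-4-yl in place of 4-bromo-3-methylphenyl on an amide-type nitrogen. For the measured compounds named here, no measured pair in this set shows this change, so nothing measured speaks to its effect. The step in this assay is expected to be modest and to run toward a higher number, that is toward weaker inhibition, with a 2.2-fold higher number from compound 2 to compound 3 (0.34 log units; beyond the scatter) as the expected size. For compound 3 the estimate in this assay is 35000 nM, with a range from 12000 nM to 100000 nM.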

Compound 3, half-maximal inhibitory concentration: 12600 nM
Compound 3: the middle estimate sits 2.8-fold (0.44 log units) above what was measured; the measured number falls inside the stated range.
By their numbers in this assay, from the lowest: compounds 3 and 2 (each within the scatter of the next); then compound 1.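

In this assay, placing 3,5-dimethylpyridin-4-yl on the amide-type nitrogen in place of 4-bromo-3-methylphenyl gives a 1.3-fold lower number from compound 2 to compound 3 (0.10 log units; within the scatter), so compound 2 and compound 3 cannot be told apart on this read-out. Among the compounds shown here, this is the first one-place comparison at this position: a ring with one hetero atom and one hydrogen-bond acceptor, without bromine, reads the same as the carbon-only ring within the scatter. Nothing available here explains this result.

The compounds shown leave open how this position responds to groups of another kind, such as an unsubstituted pyridin-4-yl or a phenyl ring carrying a carboxylic acid or an amine. Also open, as far as these compounds go, is whether 3,5-dimethylpyridin-4-yl would read the same on the branched linker of compound 1.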